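Amide aryl change on the sulfonyl compound

The compounds below may be only part of what the source reports. "The series", "measured", "known", "first", "only" and "open" are said of these compounds alone.

Measured so far in a functional assay on NUGC-3 cells (Homo sapiens) for cytotoxicity; a higher number here means a weaker inhibitor of growth, a lower number a stronger inhibitor of growth:
- compound 1 `CCCCCCCCC(=O)N1c2ccccc2CC1C(=O)Nc1ccc(C(F)(F)F)cc1`: 3450 nM
- compound 2 `Cc1ccc(S(=O)(=O)N2c3ccccc3CC2C(=O)Nc2ccc(C(F)(F)F)cc2)cc1`: > 10000 nM

For compound 2 the assay reports only a limit, (the limit of > 10000 nM in this assay, at which 1 of the 2 values shown sits); no number stands for compound 2 in this assay. For the measured compounds named here, the single measured step, an at least 2.8-fold higher number from compound 1 to compound 2 (0.46 log units; beyond the scatter), concerns the group on the nitrogen on the aromatic ring in the ring and leaves the anilide untouched.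

Compound 3 `Cc1ccc(S(=O)(=O)N2c3ccccc3CC2C(=O)Nc2cc(Cl)cc(Cl)c2)cc1` keeps the (4-methylphenyl)sulfonyl group of compound 2 and differs only at the anilide: 3,5-dichlorophenyl in place of 4-(trifluoromethyl)phenyl on an amide-type nitrogen. No measured pair in the series changes this position, so the data give neither size nor direction for this step; the one step shown lies elsewhere in the molecule.

With compound 2 sitting at the limit, the expected step from compound 2 to compound 3 is a number no higher from compound 2 to compound 3 (the limit leaves the size open), that is, nothing beyond the scatter. Compound 3 is accordingly estimated at 10000 nM, within a range of 3000 nM to 30000 nM, with a substantial chance that this assay again returns only a limit for compound 3.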

Compound 3, concentration for 50% growth inhibition: > 10000 nM
Compound 3 gave a limit, no number (the forecaster's own chance of this, stated with the estimate: 60%); the middle value lies on the limit itself.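

In this assay, for the compounds shown here, compound 3 gives > 10000 nM, a limit and not a number, and compound 2 is also a limit, so no step between the two can be read: the limit of > 10000 nM in this assay, at which 2 of the 3 values shown sit. The compounds shown leave open whether 3,5-dichlorophenyl and 4-(trifluoromethyl)phenyl on the amide-type nitrogen differ at all while the (4-methylphenyl)sulfonyl group stays in place.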